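A few compounds are considered here, and "the series" means these few. Any claim that something is new, unique, unknown or untested is made for them only; others in the source may bear on it.

Of the compounds shown here, three have so far been tested in a functional assay on microsomes for inhibition, with a stated time of 1 h; a lower number here means a stronger inhibitor, a higher number a weaker inhibitor. Compound 1 `CCOC(=O)c1cnn(-c2nc(-c3ccc(Cl)cc3)c(C#N)c(=O)n2C)c1N` gives 88 ug/mL. Compound 3 `CCOC(=O)c1cnn(-c2nc(-c3ccccc3O)c(C#N)c(=O)n2C)c1N` carries a 2-hydroxyphenyl in place of the 4-chlorophenyl of compound 1. For the measured compounds named here, compound 3 gives 57 ug/mL, so that the only measured step, a 1.5-fold lower number from compound 1 to compound 3 (0.19 log units; within the scatter), is too small to count as a real change. Compound 2 `COc1cccc(-c2nc(SC)n(C)c(=O)c2C#N)c1OC` rests on a different core and gives 48 ug/mL. The numbers of compound 3 and of compound 1 both lie within the usual scatter of that value, so on these data the three compounds cannot be told apart.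

Compound 4 `COc1cccc(-c2nc(NN)n(C)c(=O)c2C#N)c1OC` is the next step from compound 2. The change is aminoamino in place of methylsulfanyl on an aromatic carbon. Going by the values given here, no measured step bears on this exchange: the step from compound 1 to compound 3 swaps one aryl group for another on a different part of a different core, and even that step stayed within the scatter. There is thus nothing here that would point to a step beyond the scatter in either direction, and the uncertainty is wide. The expected step is a 1.0-fold higher number from compound 2 to compound 4 (0.02 log units; within the scatter). Compound 4 is therefore estimated at 50 ug/mL, with a range from 20 ug/mL to 125 ug/mL.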

Compound 4, half-maximal inhibitory concentration: 37 ug/mL
The estimate for compound 4 lay 1.4-fold (0.13 log units) above the measured number; low and high end bracket the measured number.
By their numbers in this assay, from the lowest: compounds 4, 2, 3 and 1 (each within the scatter of the next, the first and the last beyond it).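

At the aromatic carbon between two ring nitrogen atoms, the exchange of methylsulfanyl for aminoamino gives in this assay a 1.3-fold lower number from compound 2 to compound 4 (0.11 log units; within the scatter). This position therefore takes a group with 2 hydrogen-bond donors in place of one with 0 hydrogen-bond donors, and 2 nitrogen in place of 1 carbon and 1 sulfur, without a step beyond the scatter of the assay. No outside measurement is available that would help to interpret this exchange or tie it to a property of either group.

Both groups have 2 heavy atoms, so these compounds do not show what a longer chain, such as butylamino, or a carboxylic acid would do on this carbon. Going by these compounds, it also stays open whether a plain amine or a methoxy group would fall within the scatter of compound 2 as well, and whether the same exchange would give a similarly small step with the 2,3-dimethoxyphenyl group replaced by another aryl group.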